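Swapping the fluorophenyl for a chlorophenyl on the sulfonyl sulfur

The source may hold more compounds than are shown below. What is called first, only, known or untested is meant among the compounds shown, and "the series" means these compounds.

Of the compounds shown here, three sharing one core have been measured in an assay on isolated protein for displacement of a labelled ligand from metabotropic glutamate receptor 5 (Homo sapiens), with a stated time of 60 min, tested at 1 uM; on this read-out lower numbers stand for less inhibition and higher numbers for more inhibition at the one concentration tested (going by the name of the read-out). Compound 1 `CC1CCN(c2c(S(=O)(=O)c3ccc(Cl)c(Cl)c3)cnc3ccc(Cl)cc23)CC1` gives 86%, compound 2 `COc1cccc(S(=O)(=O)c2cnc3ccc(Cl)cc3c2N2CCC(C)CC2)c1` gives 87%, and compound 3 `CC1CCN(c2c(S(=O)(=O)c3cccc(F)c3)cnc3ccc(Cl)cc23)CC1` gives 58%. Compound 3 thus has the lowest of the three numbers, sitting a number 28 percentage points lower from compound 1 to compound 3 (beyond the scatter) and a number 29 percentage points lower from compound 2 to compound 3 (beyond the scatter), both beyond the scatter, while the gap a number 1 percentage points higher from compound 1 to compound 2 (within the scatter) lies within it.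

Compound 4 `CC1CCN(c2c(S(=O)(=O)c3ccc(Cl)cc3)cnc3ccc(Cl)cc23)CC1` differs from compound 3 in a single place: 4-chlorophenyl in place of 3-fluorophenyl on a sulfonyl sulfur. Within the data shown here, two measured steps touch this position. The step of a number 28 percentage points lower from compound 1 to compound 3 (beyond the scatter) shows that trading the 3,4-dichlorophenyl for the 3-fluorophenyl costs a modest amount in this assay, and the step of a number 29 percentage points lower from compound 2 to compound 3 (beyond the scatter) shows the same when methoxy gives way to fluoro. Compound 4 carries a chlorine on its phenyl ring, as compound 1 does, so the move away from the 3-fluorophenyl is expected to recover much of what was lost, giving an expected rise of a number 22 percentage points higher from compound 3 to compound 4 (beyond the scatter).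

Compound 4 is therefore estimated to reach 80%, with a likely range from 65% to 92%.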

Compound 4, a percentage reported as inhibition, at one concentration (the size of the read-out at that concentration, not a potency): 92%
Compound 4: middle estimate off by 12 percentage points, on the low side; the measured number falls inside the stated range.
By their numbers in this assay, from the lowest: compound 3; then compounds 1, 2 and 4 (each within the scatter of the next).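

The large step, a number 34 percentage points higher from compound 3 to compound 4 (beyond the scatter), shows that a single chlorine on the phenyl ring is enough to leave the low number of the 3-fluorophenyl behind, so this position on the sulfonyl sulfur responds strongly to which substituted phenyl it carries. Among these compounds, the 3,4-dichlorophenyl does not need its second chlorine here, since hydrogen in place of chloro gives a number 6 percentage points higher from compound 1 to compound 4 (within the scatter), and 4-chlorophenyl in place of 3-methoxyphenyl gives a number 5 percentage points higher from compound 2 to compound 4 (within the scatter), which leaves the 3-fluorophenyl as the only one of the four rings set apart from the others in this assay. Nothing measured here explains why that ring stands apart.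

The step to 4-chlorophenyl changes both the halogen and its place on the ring, so these compounds cannot tell which of the two matters, and a single tested concentration cannot separate the three compounds that stand level. Going by these compounds, how this position would respond to a ring carrying an amine, a carboxylic acid or a longer chain such as butoxy also remains open.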